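The source may hold more compounds than are shown below. What is called first, only, known or untested is meant among the compounds shown, and "the series" means these compounds.

Working notes on the quinolone-type amide series, all three measured compounds tested in a functional assay on A-375 cells (Homo sapiens) for antiproliferative activity, read by MTT assay, with a stated time of 24 h, tested at 0.05 ug/mL (on this read-out lower numbers stand for a weaker effect and higher numbers for a stronger effect at the one concentration tested), at a single concentration.

Compound 1 `Cc1ccc2nc(C(=O)Nc3c(F)cc(-c4cccc(F)c4)cc3F)c(C)c(O)c2c1` gives 0.96%. Compound 2 `Cc1c(C(=O)Nc2c(F)cc(-c3cccc(F)c3)cc2F)nc2ccc(F)cc2c1O` gives 0.05%. Compound 3 `CCOc1ccc2nc(C(=O)Nc3c(F)cc(-c4cccc(F)c4)cc3F)c(C)c(O)c2c1` gives 1.02%. Going by the values given here, every number so far sits close to zero, and each pairwise step stays within the scatter: a number 0.9 percentage points lower from compound 1 to compound 2 (within the scatter), a number 0.1 percentage points higher from compound 1 to compound 3 (within the scatter), a number 1 percentage points higher from compound 2 to compound 3 (within the scatter). Compound 3 therefore stands alongside the other two rather than apart from them, its separation from compound 1 a number 0.1 percentage points higher from compound 1 to compound 3 (within the scatter) and from compound 2 a number 1 percentage points higher from compound 2 to compound 3 (within the scatter) both inside the usual noise.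

Compound 4 `Cc1c(C(=O)Nc2c(F)cc(-c3cccc(F)c3)cc2F)nc2ccc(C(F)(F)F)cc2c1O` is the next variant at the same aromatic carbon: trifluoromethyl in place of ethoxy on an aromatic carbon. Among the compounds with values here, the steps that bear on it are those that already exchanged groups at this position, methyl to ethoxy and fluoro to ethoxy, and neither moved this assay beyond the scatter. Within the data shown here, no measured step speaks to trifluoromethyl itself, but the three substituents tried so far, differing in size and in acceptor count, all returned the same near-zero read-out. The expected step is accordingly a number 0 percentage points lower from compound 3 to compound 4 (within the scatter), none beyond the scatter. Compound 4 is estimated at 1%, with a range from -4% to 6%.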

Compound 4, a percentage reported as inhibition, at one concentration (the size of the read-out at that concentration, not a potency): 3.47%
Compound 4: middle estimate off by 2.5 percentage points, on the low side; the measured number falls inside the stated range.
By their numbers in this assay, from the lowest: compounds 2, 1, 3 and 4 (each within the scatter of the next).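

In this assay, trifluoromethyl on this aromatic carbon stays within the scatter of all three earlier groups, with ethoxy (a number 2.5 percentage points higher from compound 3 to compound 4 (within the scatter)), fluoro (a number 3.4 percentage points higher from compound 2 to compound 4 (within the scatter)) and methyl (a number 2.5 percentage points higher from compound 1 to compound 4 (within the scatter)). The position has now taken four substituents, from fluoro to trifluoromethyl, and the last of these brings in three fluorine atoms and no hydrogen-bond acceptor, yet no exchange among the four compounds has moved the read-out beyond the scatter at the one concentration tested. No measurement on these compounds offers an explanation for this flat picture.

Still open, from the compounds shown here alone, is whether an amine or a carboxylic acid on this aromatic carbon would give a read-out that stands apart from the four compounds, or whether this position simply has no bearing on the read-out at this concentration. Also open, going by these compounds, is whether the four compounds would separate at a higher concentration, and whether replacing the hydroxyl or the methyl elsewhere on the shared core would change the result.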